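Methyl in place of hydrogen on the aryl ring, compound 4

The source may hold more compounds than are shown below. What is called first, only, known or untested is meant among the compounds shown, and "the series" means these compounds.

Among the measured compounds shown here, compound 3 `O=C(Nc1ccc(Oc2ncnc3ccsc23)c(F)c1)c1nn(-c2ccccc2)ccc1=O` stands highest of the three measured members, that is weakest. In a functional assay on A549 cells (Homo sapiens) for cytotoxicity, read by MTT assay, with a stated time of 72 h (a higher number here means a weaker inhibitor, a lower number a stronger inhibitor), compound 3 gives 19700 nM, whereas compound 1 `O=C(Nc1ccc(Oc2ncnc3ccsc23)c(F)c1)c1nn(-c2ccc(F)cc2)ccc1=O` gives 8230 nM and compound 2 `O=C(Nc1ccc(Oc2ncnc3ccsc23)c(F)c1)c1nn(-c2ccc(F)c(Cl)c2)ccc1=O` gives 9650 nM. Both steps up to compound 3 lie beyond the scatter: a 2.4-fold higher number from compound 1 to compound 3 (0.38 log units; beyond the scatter) and a 2.0-fold higher number from compound 2 to compound 3 (0.31 log units; beyond the scatter).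

Compound 4 `Cc1ccc(-n2ccc(=O)c(C(=O)Nc3ccc(Oc4ncnc5ccsc45)c(F)c3)n2)cc1` differs from compound 3 in one place: methyl in place of hydrogen on an aromatic carbon. For the measured compounds named here, two measured steps bear on a small group on this ring. Removing fluoro from the six-membered ring of carbon only raised the number modestly, a 2.4-fold higher number from compound 1 to compound 3 (0.38 log units; beyond the scatter), so a small group at this aromatic carbon appears to help a little. Adding chloro to that ring changed nothing beyond the scatter, a 1.2-fold higher number from compound 1 to compound 2 (0.07 log units; within the scatter). A methyl entering at the carbon that carries fluoro in compound 1 is therefore expected to lower the number by a modest amount, near the size of the fluoro step or smaller, a 1.6-fold lower number from compound 3 to compound 4 (0.22 log units; within the scatter). Going by the values given here, no methyl step exists among the measured pairs, so the expectation is loosely held and a result within the scatter of compound 3 would not surprise. Compound 4 is expected to give 12000 nM in this assay, with a range of 6000 nM to 25000 nM.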

Compound 4, half-maximal inhibitory concentration: 11600 nM
For compound 4 the middle estimate is 1.0-fold (0.01 log units) above the measured one; the range from low to high includes it.
By their numbers in this assay, from the lowest: compounds 1, 2, 4 and 3 (each within the scatter of the next, the first and the last beyond it).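

In this assay, the methyl step at the aromatic carbon para to a large group, a 1.7-fold lower number from compound 3 to compound 4 (0.23 log units; within the scatter), stays within the scatter, so phenyl and 4-methylphenyl are not separated at this position. Methyl is also not separated from fluoro at this carbon (a 1.4-fold higher number from compound 1 to compound 4 (0.15 log units; within the scatter)) or from the 3-chloro-4-fluorophenyl group (a 1.2-fold higher number from compound 2 to compound 4 (0.08 log units; within the scatter)), while the fluoro-to-hydrogen step (a 2.4-fold higher number from compound 1 to compound 3 (0.38 log units; beyond the scatter)) lies beyond it, so compound 4 falls within the scatter of all three earlier compounds and does not show whether the gain tracks with fluoro specifically or with any small group at this carbon. No measurement on these compounds offers an explanation for these steps.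

Open, going by these compounds, is whether a methoxy group, a dimethylamino group or a carboxylic acid at this carbon would move the number beyond the scatter of compound 3 in either direction. Also open is whether a chloro group alone, or a methyl group at the carbon that carries chloro in compound 2, would be told apart from the members shown.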